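A few compounds are considered here, and "the series" means these few. Any claim that something is new, unique, unknown or untested is made for them only; others in the source may bear on it.

In a functional assay on MGC-803 cells (Homo sapiens) for cytotoxicity, read by MTT assay, with a stated time of 72 h (on this read-out lower numbers stand for stronger inhibition and higher numbers for weaker inhibition), compound 1 `CCCCCCNc1nc(SCc2ccc(C(F)(F)F)cc2)nc2ccccc12` gives 13100 nM and compound 2 `FC(F)(F)c1ccc(CSc2nc(Nc3cccc(Br)c3)c3ccccc3n2)cc1` gives 23700 nM. Compound 3 `COc1ccc(Nc2nc(SCc3ccc(C(F)(F)F)cc3)nc3ccccc23)c(OC)c1` reaches only the limit of the assay, > 50000 nM. Compound 3 thus stands at the weak end of the set, shown by an at least 3.8-fold higher number from compound 1 to compound 3 (0.58 log units; beyond the scatter) and by an at least 2.1-fold higher number from compound 2 to compound 3 (0.32 log units; beyond the scatter). Compound 4 `Fc1ccc(Nc2nc(SCc3ccc(C(F)(F)F)cc3)nc3ccccc23)cc1Cl` differs from compound 3 by 3-chloro-4-fluorophenyl in place of 2,4-dimethoxyphenyl on a nitrogen on an aromatic ring. Among the measured compounds shown here, the steps that bear on this change are the two leading into compound 3, both ending at the limit of > 50000 nM in this assay, at which 1 of the 3 values shown sits, and both modest in size; going back from a dimethoxyphenyl to a halogenated phenyl is expected to bring the number down toward that of compound 2. Compound 4 is therefore estimated at 25000 nM, with a range from 10000 nM to 60000 nM, an expected step of an at least 2.0-fold lower number from compound 3 to compound 4 (0.30 log units; that floor lies within the scatter).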

Compound 4, half-maximal inhibitory concentration: > 50000 nM
Compound 4 gave a limit, no number; the forecaster's own chance of this, stated with the estimate: 30%; middle value at least 2.0-fold (0.30 log units) from the limit.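

A halogenated phenyl on this nitrogen does not by itself keep the number in the measurable range: there is an at least 2.1-fold higher number from compound 2 to compound 4 (0.32 log units; beyond the scatter), where 3-chloro-4-fluorophenyl replaces 3-bromophenyl. Against the hexyl compound, there is an at least 3.8-fold higher number from compound 1 to compound 4 (0.58 log units; beyond the scatter). The step from compound 3 to compound 4 cannot be read, because both values are limits of the assay: the limit of > 50000 nM in this assay, at which 2 of the 4 values shown sit.

As far as these compounds go, whether an octyl chain or a morpholine on this nitrogen would give a lower number than compound 1 stays open. So does the outcome with a single chlorine or a single fluorine on the phenyl ring.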